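Ethylpiperidine amide exchanged for a sulfonamide-bearing chain

This account rests on a few compounds, and the source may have more. Where it says the series, first, only, none or still open, it means among the compounds named here.

Within the data shown here, compound 2 `CCC1CCCN(C(=O)CN2CN(c3ccccc3)C3(CCN(C(=O)c4ccc(C(C)(C)C)cc4)CC3)C2=O)C1` holds the lowest of the two numbers measured so far; in an assay on HEK293 cells for displacement of a labelled ligand from NPC1-like intracellular cholesterol transporter 1 (Homo sapiens) (on this read-out higher numbers stand for weaker inhibition and lower numbers for stronger inhibition), compound 2 gives 3900 nM. Among the measured compounds shown here, its only neighbour, compound 1 `CC(C)(C)c1ccc(C(=O)N2CCC3(CC2)C(=O)N(CC(=O)NCN)CN3c2ccccc2)cc1`, gives 26500 nM in this assay, and the single measured step, a 6.8-fold lower number from compound 1 to compound 2 (0.83 log units; beyond the scatter), accompanied the move from an open-chain amino group to the ring amine. Compound 3 `CC(C)(C)c1ccc(C(=O)N2CCC3(CC2)C(=O)N(CC(=O)NCCCNS(C)(=O)=O)CN3c2ccccc2)cc1` returns to an open-chain amino substituent: (3-(methanesulfonamido)propyl)amino in place of 3-ethylpiperidin-1-yl on a carbonyl carbon. For the measured compounds named here, that earlier step is the sole guide, so compound 3 is expected to move back toward the number of compound 1, with a 3.8-fold higher number from compound 2 to compound 3 (0.59 log units; beyond the scatter). The estimate for compound 3 is 15000 nM, range 5000 nM to 45000 nM.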

Compound 3, half-maximal inhibitory concentration: 10400 nM
For compound 3 the middle estimate is 1.4-fold (0.16 log units) above the measured one; measured number inside the range.
By their numbers in this assay, from the lowest: compound 2; then compound 3; then compound 1.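

On this carbonyl carbon, an open-chain amino substituent does not by itself return the number to that of compound 1: replacing the amino end with 2-(methanesulfonamido)ethyl gives (a 2.5-fold lower number from compound 1 to compound 3 (0.41 log units; beyond the scatter)). The ring amine still holds the lowest number in this assay, with (3-(methanesulfonamido)propyl)amino in its place giving (a 2.7-fold higher number from compound 2 to compound 3 (0.43 log units; beyond the scatter)). No measurement here accounts for either step.

The compounds shown do not separate the contribution of chain length from that of the methanesulfonamide end. A plain propyl chain or a terminal carboxylic acid on this carbonyl carbon would test that separation.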